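This account rests on a few compounds, and the source may have more. Where it says the series, first, only, none or still open, it means among the compounds named here.

In a functional assay on T98G cells (Homo sapiens) for cytotoxicity, read by MTT assay, with a stated time of 48 h (on this read-out higher numbers stand for weaker inhibition and lower numbers for stronger inhibition), compound 1 (`CC(=NNC(=S)Nc1ccccc1)c1ccccn1`) gives 6.8 nM and compound 2 (`CC(=NNC(=S)Nc1ccc(Cl)cc1)c1ccccn1`) gives 5.9 nM, two values within the scatter of each other. Compound 3 (`CC(=NNC(=S)Nc1ccc([N+](=O)[O-])cc1)c1ccccn1`) carries nitro in place of chloro on an aromatic carbon. For the measured compounds named here, the one measured step that bears on this change, a 1.2-fold lower number from compound 1 to compound 2 (0.06 log units; within the scatter), also swaps a group at that place, but no measured compound carries nitro, so the evidence is thin. The expected change in this assay is therefore none beyond the scatter, an estimated 1.2-fold lower number from compound 2 to compound 3 (0.07 log units; within the scatter). Compound 3 is expected at 5 nM, with an estimated range from 1.8 nM to 15 nM.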

Compound 3, half-maximal inhibitory concentration: 140 nM
Compound 3: the middle estimate sits 28-fold (1.45 log units) below what was measured; measured number outside the range, above it.
By their numbers in this assay, from the lowest: compounds 2 and 1 (each within the scatter of the next); then compound 3.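

In this assay, the place para to a large group turns out not to be indifferent to what it carries: nitro in place of chloro gives a 24-fold higher number from compound 2 to compound 3 (1.38 log units; beyond the scatter), and nitro in place of hydrogen gives a 21-fold higher number from compound 1 to compound 3 (1.31 log units; beyond the scatter). Compound 1 and compound 2 stood within the scatter of each other, so only with nitro does a change at this place show a clear weakening of inhibition. Nothing at hand accounts for this change. From the compounds shown here alone, it remains open whether this weakening is peculiar to nitro or would also appear with an amine, a methoxy group or a carboxylic acid at this place. Going by these compounds, it is equally open whether nitro elsewhere on the ring would give the same result.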